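Methoxy removal on the aryl ring: towards compound 4

The source may hold more compounds than are shown below. What is called first, only, known or untested is meant among the compounds shown, and "the series" means these compounds.

Measured compounds and values in a functional assay on IGROV-1 cells (Homo sapiens) for inhibition, read by sulforhodamine B assay, with a stated time of 48 h; on this read-out lower numbers stand for stronger inhibition of growth and higher numbers for weaker inhibition of growth:
- compound 1 `COc1ccc(-c2cc(/C=C/C(=O)c3ccc(N)cc3)[nH]n2)cc1` gives 2270 nM
- compound 2 `COc1ccc(-c2cc(/C=C/C(=O)c3ccc(N)cc3)[nH]n2)cc1OC` gives 4560 nM
- compound 3 `COc1cc(C(=O)/C=C/c2cc(-c3cc(OC)c(OC)c(OC)c3)n[nH]2)cc(OC)c1OC` gives 3140 nM

Compound 1 and compound 2 differ in one place only, (hydrogen in place of methoxy on an aromatic carbon). In this assay this gave a 2.0-fold lower number from compound 2 to compound 1 (0.30 log units; within the scatter), a step that is within the scatter, so the two values cannot be ordered with confidence.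

Compound 3 carries a different core; how the core of compound 3 differs from the core of compound 2 is not broken down here. Its value in this assay lies between the other two, within the scatter of both.

Compound 4 `COc1ccc(-c2cc(/C=C/C(=O)c3cc(OC)c(OC)c(OC)c3)[nH]n2)cc1OC` is not yet measured. It differs from compound 3 by hydrogen in place of methoxy on an aromatic carbon. The surroundings are not identical to those of the earlier change: in compound 3 the carbon is also meta to a methoxy group, which is not the case in compound 2, so this is the same kind of change rather than the same change.

Among the compounds with values here, the only precedent is the step from compound 2 to compound 1. Resting on a 2.0-fold lower number from compound 2 to compound 1 (0.30 log units; within the scatter), a step of similar size is expected, a 1.7-fold lower number from compound 3 to compound 4 (0.24 log units; within the scatter), with wide uncertainty since the single precedent itself lies within the scatter. Compound 4 is thus estimated at 1800 nM in this assay, most likely between 700 nM and 5000 nM.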

Compound 4, concentration for 50% growth inhibition: 2720 nM
Beside the measured number, compound 4's estimate is 1.5-fold (0.18 log units) below it; low and high end bracket the measured number.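

In this assay, hydrogen in place of methoxy on an aromatic carbon gave a 1.2-fold lower number from compound 3 to compound 4 (0.06 log units; within the scatter), so this step, like the earlier one, cannot be read as a real change. Set side by side, the two steps cannot be told apart: the same change on two cores in this assay, a 2.0-fold lower number (0.30 log units; within the scatter) from compound 2 to compound 1 and a 1.2-fold lower number (0.06 log units; within the scatter) from compound 3 to compound 4, 1.7-fold (0.24 log units) apart, within the scatter of two such steps. This shows that, across these two cores, the replacement leaves the growth-inhibition number within the scatter and that nothing here marks one core as responding differently from the other; it does not show that the replacement has a real effect in either direction, and two small steps on two cores give no assurance about a further core.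

The compounds shown carry only methoxy or hydrogen at the changed aromatic carbon, so it remains open whether another group there, such as hydroxy, chlorine or a carboxylic acid, would give a step beyond the scatter. As far as these compounds go, it also remains open whether taking away the remaining methoxy groups, singly or together, would shift the number by more than these single replacements did.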